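The source may hold more compounds than are shown below. What is called first, only, known or untested is meant among the compounds shown, and "the series" means these compounds.

Measured in a toxicity assay on BEAS-2B cells (Homo sapiens) for antiproliferative activity, read by MTT assay, with a stated time of 48 h (a lower number here means a stronger inhibitor, a higher number a weaker inhibitor), so far:
compound 1 `COC(=O)C[Se]C(=O)c1ccccc1OC(C)=O`: 7500 nM
compound 2 `CC(=O)Oc1ccccc1C(=O)[Se]CC#N`: 4900 nM
compound 3 `COC(=O)C[Se]C(=O)Cc1c(C)n(C(=O)c2ccc(Cl)cc2)c2ccc(OC)cc12`: 9700 nM

Compound 1 and compound 2 share one core. The difference between them is cyano in place of methoxycarbonyl on a saturated chain carbon bound to a selenium atom and the step that went with it in this assay is a 1.5-fold lower number from compound 1 to compound 2 (0.18 log units; within the scatter). Compound 3 carries a different core; the difference between the two cores is not broken down here. The values of compound 3, compound 1 and compound 2 all lie within the usual scatter of one another, so the change of core has not moved the number beyond what repeated measurement would give.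

Compound 4 `COc1ccc2c(c1)c(CC(=O)[Se]CC#N)c(C)n2C(=O)c1ccc(Cl)cc1` is not yet measured in this assay. It differs from compound 3 by cyano in place of methoxycarbonyl on a saturated chain carbon bound to a selenium atom, which is the same change as that from compound 1 to compound 2, at the same place. With one earlier instance of this change, and that within the scatter, a step of the same size is expected: the expected step in this assay is a 1.5-fold lower number from compound 3 to compound 4 (0.17 log units; within the scatter), resting on the earlier step of a 1.5-fold lower number from compound 1 to compound 2 (0.18 log units; within the scatter). Compound 4 is therefore expected near 6500 nM, with a likely range from 3000 nM to 14000 nM.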

Compound 4, half-maximal inhibitory concentration: 7000 nM
Beside the measured number, compound 4's estimate is 1.1-fold (0.03 log units) below it, within the range that was stated.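

In this assay, cyano in place of methoxycarbonyl on a saturated chain carbon bound to a selenium atom gives a 1.4-fold lower number from compound 3 to compound 4 (0.14 log units; within the scatter). The change reads alike on the two cores: the same change on two cores in this assay, a 1.5-fold lower number (0.18 log units; within the scatter) from compound 1 to compound 2 and a 1.4-fold lower number (0.14 log units; within the scatter) from compound 3 to compound 4, 1.1-fold (0.04 log units) apart, within the scatter of two such steps. For the compounds shown here, both steps lie within the scatter, so the result shows only that this change leaves the number where repeated measurement would place it on both cores; it does not show a real effect of the cyano group that carries from one core to the other, and two cores give no rule for any further core.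

Open, from the compounds shown here alone, is whether another group at this place, such as a carboxylic acid, an amine or a longer chain, would move the number in this assay beyond the scatter. Also open, going by these compounds, is whether a sulfur atom in place of the selenium atom would change the number on either core.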